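The source may hold more compounds than are shown below. What is called first, only, known or untested is meant among the compounds shown, and "the series" means these compounds.

Compound 1 `Cc1cc(-c2ccccc2)n(/C(N)=N/S(=O)(=O)c2cc(C)c(Cl)cc2SCc2cccc(Cl)c2)n1` and compound 2 `Cc1cc(S(=O)(=O)/N=C(\N)n2nccc2-c2ccccc2)c(SCc2ccccc2Cl)cc1Cl` share one core and differ only in where the chlorine sits on the benzyl thioether. In a functional assay on MCF7 cells (Homo sapiens) for cytotoxicity, read by MTT assay, with a stated time of 72 h (on this read-out lower numbers stand for stronger inhibition and higher numbers for weaker inhibition), compound 1 gives 25000 nM. In this assay compound 2 gives 24000 nM, which stands within the scatter of the value for compound 1, so the two cannot be ranked. Compound 3 `Cc1cc(-c2ccccc2)n(/C(N)=N/S(=O)(=O)c2cc(C)c(Cl)cc2SCc2ccccc2Cl)n1` is reached from compound 2 by methyl in place of hydrogen on an aromatic carbon. Among the compounds with values here, no measured pair shows this change, so no step beyond the scatter is expected in either direction. Compound 3 is therefore estimated at 24000 nM, with a range from 10000 nM to 60000 nM, meaning an expected step of no change at the digits printed from compound 2 to compound 3 (within the scatter).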

Compound 3, half-maximal inhibitory concentration: 135000 nM
Compound 3: middle estimate off by 5.6-fold (0.75 log units), on the low side; the measured number lies above the stated range.
By their numbers in this assay, from the lowest: compounds 2 and 1 (each within the scatter of the next); then compound 3.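

In this assay, methyl in place of hydrogen on this ring carbon is not a neutral change: it gives a 5.6-fold higher number from compound 2 to compound 3 (0.75 log units; beyond the scatter). With that methyl present, the chlorine's place on the benzyl thioether also counts, as 2-chlorophenyl in place of 3-chlorophenyl gives a 5.4-fold higher number from compound 1 to compound 3 (0.73 log units; beyond the scatter). Nothing measured here offers a reason for either step. From the compounds shown here alone, whether an ethyl chain or an amine on this ring carbon would behave like methyl stays open. Each change is seen only once, so neither step can be called a general rule.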